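This account rests on a few compounds, and the source may have more. Where it says the series, first, only, none or still open, it means among the compounds named here.

Values in an ADME assay on HepG2 cells (Homo sapiens) for cytotoxicity, with a stated time of 3 days (a lower number here means that less compound is tolerated, a higher number that more compound is tolerated), for the measured members of the series:

compound 1 `CC(Sc1nnc(-c2ccncc2)s1)C(=O)Nc1ccc(Cl)cc1Cl`: > 50000 nM, a limit of the assay and not a number.
compound 2 `CC(Sc1nnc(-c2ccncc2)s1)C(=O)Nc1c(Cl)cccc1Cl`: > 50000 nM, likewise a limit and not a number.
compound 3 `O=C(CCSc1nnc(-c2ccncc2)s1)Nc1c(Cl)cccc1Cl`: 12600 nM, the only number among the three.

Compound 1 and compound 2 share one core and differ by 2,4-dichlorophenyl in place of 2,6-dichlorophenyl on an amide-type nitrogen. The step that the two limits leave unreadable from compound 2 to compound 1 cannot be sized, since both values sit at the limit of > 50000 nM in this assay, at which 2 of the 3 values shown sit. Compound 3 carries the same 2,6-dichlorophenyl group on the amide-type nitrogen as compound 2 but on a different core; how the two cores differ is not broken down here. Among the compounds with values here, compound 3 in this assay stands as the one value that is a number rather than a limit.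

Compound 4 `O=C(CCSc1nnc(-c2ccncc2)s1)Nc1ccc(Cl)cc1Cl` has not yet been measured in this assay. It differs from compound 3 by 2,4-dichlorophenyl in place of 2,6-dichlorophenyl on an amide-type nitrogen, the same change as that from compound 2 to compound 1, made at the same place; among the compounds shown this change occurs twice.

Compound 4 is expected to give about 20000 nM in this assay. The expected range for compound 4 runs from 8000 nM to 60000 nM. The expected step of a 1.6-fold higher number from compound 3 to compound 4 (0.20 log units; within the scatter) is kept small. Within the data shown here, this rests on compound 3 at 12600 nM being the only number available and on the step that the two limits leave unreadable from compound 2 to compound 1, which gives no readable size for the same change. A result that again comes out as a limit rather than a number is a real possibility for compound 4.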

Compound 4, half-maximal cytotoxic concentration: > 50000 nM
Compound 4: no number, only a limit (the forecaster's own chance of this, stated with the estimate: 35%); middle value at least 2.5-fold (0.39 log units) away from the limit.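

In this assay, 2,4-dichlorophenyl in place of 2,6-dichlorophenyl on the amide-type nitrogen gives an at least 3.9-fold higher number from compound 3 to compound 4 (0.59 log units; beyond the scatter), and as the value of compound 4 is a limit and not a number, this size is a lower bound only. The same change on the core of compound 1 and compound 2 cannot be read, as both of those values are limits, so the change has a readable direction on one core only, and the two cores do not show that its size carries over from one to the other. The results on the two cores do not conflict, but they offer no true comparison, and only compound 3 gives a number: the limit of > 50000 nM in this assay, at which 3 of the 4 values shown sit.

Going by these compounds, the true size of the step on either core stays open, as does whether the higher number on the core of compound 3 would hold for other groups on the amide-type nitrogen. Also open, on these data alone, is how an amine or a carboxylic acid in place of the dichlorophenyl group would read in this assay, and whether a longer chain on the core of compound 3 would give a number or a limit.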